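The source may hold more compounds than are shown below. What is called first, only, known or untested is meant among the compounds shown, and "the series" means these compounds.

Working notes on the series. Among the compounds with values here, in a functional assay on MCF7 cells (Homo sapiens) for cytotoxicity, read by MTT assay, with a stated time of 48 h (on this read-out higher numbers stand for weaker inhibition and lower numbers for stronger inhibition), compound 1 (`O=C1/C(=C\c2ccccc2)S/C(=N/c2ccccc2)N1Cc1ccncc1`) gives 26400 nM and compound 2 (`COc1ccc(/C=C2/S/C(=N/c3ccccc3)N(Cc3ccncc3)C2=O)cc1`) gives 31500 nM, so compound 2 stands level with compound 1, the only other measured member. Compound 3 (`CC(C)c1ccc(/C=C2/S/C(=N/c3ccccc3)N(Cc3ccncc3)C2=O)cc1`) is not yet measured. It has isopropyl in place of methoxy on an aromatic carbon, para to a large group, a change of 4-methoxyphenyl to 4-isopropylphenyl: isopropyl in place of methoxy on an aromatic carbon. Within the data shown here, no measured step makes this exact exchange. Among the measured compounds shown here, the one step that bears on it is a 1.2-fold higher number from compound 1 to compound 2 (0.08 log units; within the scatter), where methoxy took the place of hydrogen on that aromatic carbon. Going by these compounds, on that evidence, no step beyond the scatter is expected in this assay, and the direction stays open. The estimated step is a 1.2-fold lower number from compound 2 to compound 3 (0.07 log units; within the scatter). For compound 3 the expected value is 27000 nM, with an estimated range of 12000 nM to 55000 nM.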

Compound 3, half-maximal inhibitory concentration: 53300 nM
The estimate for compound 3 lay 2.0-fold (0.30 log units) below the measured number, and the stated range covers the measured number.
By their numbers in this assay, from the lowest: compounds 1, 2 and 3 (each within the scatter of the next, the first and the last beyond it).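

In this assay, within the data shown here, this aromatic carbon, para to a large group, gives the first step beyond the scatter, and it comes with isopropyl in place of hydrogen (a 2.0-fold higher number from compound 1 to compound 3 (0.31 log units; beyond the scatter)). The exchange of methoxy for isopropyl at the same carbon stays within the scatter (a 1.7-fold higher number from compound 2 to compound 3 (0.23 log units; within the scatter)), so compound 2 cannot be separated from either neighbour and the three groups do not yet form a firm order. Nothing available explains the modest step from hydrogen to isopropyl.

Going by these compounds, whether an amine, a carboxylic acid or a longer chain on this carbon would give a larger step, or one in the opposite direction, stays open. Also open, on these data alone, is whether isopropyl gives a similar step elsewhere on this ring.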